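Swapping the methyl position on a piperazine aryl ring

The compounds below may be only part of what the source reports. "The series", "measured", "known", "first", "only" and "open" are said of these compounds alone.

Three compounds share a core and were tested in an assay on HEK293 cells for inhibition of Voltage-dependent T-type calcium channel subunit alpha-1G (Homo sapiens), read by fluorescence, tested at 10 uM; on this read-out higher numbers stand for more inhibition at the one concentration tested (going by the name of the read-out) and lower numbers for less inhibition. Compound 2 `CCCc1nc(-c2ccccc2)c(CNCCN2CCN(c3ccc(C)cc3)CC2)o1` gives 48.1%. Compound 1 `CCCc1nc(-c2ccccc2)c(CNCCN2CCN(c3cccc(C)c3)CC2)o1`, made by the change (3-methylphenyl in place of 4-methylphenyl on an amine nitrogen in a ring), gives 43.1%, a step of a number 5 percentage points lower from compound 2 to compound 1 (within the scatter). Compound 3 `CCCc1nc(-c2ccccc2)c(CNCCCN2CCN(c3ccc(C)cc3)CC2)o1` gives 53.9%; the difference between its core and that of compound 2 is not broken down here. Compound 4 `CCCc1nc(-c2ccccc2)c(CNCCCN2CCN(c3cccc(C)c3)CC2)o1` differs from compound 3 by 3-methylphenyl in place of 4-methylphenyl on an amine nitrogen in a ring, the same change as between compound 2 and compound 1, at the same place. Because the earlier step was a number 5 percentage points lower from compound 2 to compound 1 (within the scatter), a step of similar size, a number 4.9 percentage points lower from compound 3 to compound 4 (within the scatter), is expected from compound 3 to compound 4. Compound 4 is therefore estimated to give 49% in this assay, expected to lie between 36% and 62%.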

Compound 4, a percentage reported as inhibition, at one concentration (the size of the read-out at that concentration, not a potency): 47.8%
Compound 4: the middle estimate sits 1.2 percentage points above what was measured, and the stated range covers the measured number.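

In this assay, 3-methylphenyl in place of 4-methylphenyl gives a number 6.1 percentage points lower from compound 3 to compound 4 (within the scatter). Set beside the same change on the other core, the two steps agree: the same change on two cores in this assay, a number 5 percentage points lower (within the scatter) from compound 2 to compound 1 and a number 6.1 percentage points lower (within the scatter) from compound 3 to compound 4, 1.1 percentage points apart, within the scatter of two such steps This shows that the change behaved alike on these two cores, but neither step alone lies beyond the scatter, so it does not show that the methyl position itself matters for inhibition, and two cores cannot establish a rule for the whole series.

The compounds shown leave open what a chlorine or a methoxy group in place of the methyl would give. For the compounds shown here, they also leave open what a longer chain than the one in compound 3 would give.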